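Chloro in place of fluoro on compound 3

The source may report more compounds than this note shows. Statements on the series, on what has been measured and on what is new or still open speak of the compounds shown alone.

Compound 1 `C=C[C@@](C)(/C=C/c1ccc(OC)cc1)CCC=C(C)C` and compound 2 `C=C[C@@](C)(/C=C/c1ccc(Nc2ccccc2)cc1)CCC=C(C)C` and compound 3 `C=C[C@@](C)(/C=C/c1ccc(-c2ccc(F)cc2)cc1)CCC=C(C)C` share one core, and compound 4 `C=C[C@@](C)(/C=C/c1ccc(-c2ccc(Cl)cc2)cc1)CCC=C(C)C` remains unmeasured. In an ADME assay on HEK293 cells (Homo sapiens) for cytotoxicity, with a stated time of 72 h (on this read-out lower numbers stand for an effect already at smaller amounts and higher numbers for an effect only at larger amounts of compound), compound 1 gives > 36600 nM as a limit of the assay and not a number. Compound 2 gives > 36600 nM as a limit too. Compound 3 likewise stands only at a limit with > 36600 nM as its entry. Going by the values given here, the series so far reads as the limit of > 36600 nM in this assay, at which 3 of the 3 values shown sit, and nothing more.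

The change to compound 4 is chloro in place of fluoro on an aromatic carbon with chloro in place of fluoro on an aromatic carbon para to a large group. Among the compounds with values here, three measured steps bear on it: a step that the two limits leave unreadable from compound 1 to compound 3 and a step that the two limits leave unreadable from compound 2 to compound 3 and a step that the two limits leave unreadable from compound 1 to compound 2 offer no size to carry over. The expected step is a step that the limit leaves unreadable from compound 3 to compound 4 with no direction favoured and nothing beyond the scatter expected in this assay for this change. Compound 4 is expected to report a limit as well. For compound 4 the estimate is 40000 nM with an expected range from 20000 nM to 80000 nM as its span.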

Compound 4, half-maximal effective concentration: > 36600 nM
Compound 4 gave a limit, no number; the forecaster's own chance of this, stated with the estimate: 85%; the middle value does not contradict the limit.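

Compound 4, like compound 1, compound 2 and compound 3, gives only a limit of the assay and not a number, so no step among them can be read: the limit of > 36600 nM in this assay, at which 4 of the 4 values shown sit.

The compounds shown leave open at what concentration any of them would show an effect in this assay, and whether chloro and fluoro differ there.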